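This account rests on a few compounds, and the source may have more. Where it says the series, first, only, none or still open, it means among the compounds named here.

Compound 1, `CCOC(=O)CCCCCOc1cccc(CN(C(=O)c2ccc(-c3ccc4ccccc4c3)cc2)C(C)C)c1`: in an ADME assay on HepG2 cells (Homo sapiens) for cytotoxicity, read by CellTiter-Glo and resazurin assay, with a stated time of 72 h (on this read-out higher numbers stand for an effect only at larger amounts of compound and lower numbers for an effect already at smaller amounts), compound 1 gives > 26000 nM, which is a limit of the assay and not a number.
Compound 2, `CCOC(=O)CCCCCOc1cccc(CN(C(=O)c2ccc(-c3cccc(Oc4ccccc4)c3)cc2)C(C)C)c1`: in this assay compound 2 gives > 26000 nM, likewise a limit.
Compound 3, `CCOC(=O)CCCCCOc1cccc(CN(C(=O)c2ccc(-c3cccc(Cl)c3)cc2)C(C)C)c1`: in this assay compound 3 gives > 18400 nM, again a limit.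

Compound 3 therefore stands where every measured compound stands: no number has been found for any of the three, only a limit. Two of the values sit at the limit of > 26000 nM in this assay, at which 2 of the 3 values shown sit, and one at the limit of > 18400 nM in this assay, at which 1 of the 3 values shown sits. For that reason the two steps that lead to compound 3, a step that the two limits leave unreadable from compound 1 to compound 3 and a step that the two limits leave unreadable from compound 2 to compound 3, can be read in neither size nor direction.

Compound 4, `CCOC(=O)CCCCCOc1cccc(CN(C(=O)c2ccc(-c3cccc(S(C)(=O)=O)c3)cc2)C(C)C)c1`, differs from compound 3 by methylsulfonyl in place of chloro on an aromatic carbon. Both measured steps altered the same part of the shared core as this change does, and both were left unreadable by the limits, so they give no size and no direction to carry over. What they do show is that three variations at this position all left the effect beyond the reach of the assay. Compound 4 is therefore expected to give about 26000 nM, with a range from 12000 nM to 60000 nM, most probably reported once more only as a limit. The expected step that the limit leaves unreadable from compound 3 to compound 4 means no change beyond the scatter.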

Compound 4, half-maximal effective concentration: > 26000 nM
Compound 4: a limit, no number; the forecaster's own chance of this, stated with the estimate: 85%; the middle value sits exactly at the limit.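

In this assay compound 4 gives > 26000 nM, a limit of the assay and not a number. Among the compounds shown here, compound 1, compound 2 and compound 3 also have only limits, and no step joining compound 4 to any of them can be read in size or direction. The compounds shown leave open at what concentration any of the four would show an effect in this assay, and whether the changed group matters.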